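Methylamide in place of the acid-bearing group

The compounds below may be only part of what the source reports. "The series", "measured", "known", "first", "only" and "open" are said of these compounds alone.

Compound 2 `O=C(O)CSc1ccc(NCc2cccc(Oc3ccccc3)c2)cc1` has been measured in a functional assay on CHO cells for agonist activity at Free fatty acid receptor 1 (Homo sapiens), read by a luciferase reporter (a lower number here means a smaller maximal response, a higher number a larger maximal response), and gives 84%. Going by the values given here, compound 1 `O=C(O)/C=C/c1ccc(NCc2cccc(Oc3ccccc3)c2)cc1` gives 76% in this assay; the one measured step, a number 8 percentage points higher from compound 1 to compound 2 (within the scatter), leaves the two numbers within the scatter of each other, so compound 2 cannot be set apart from compound 1 on the maximal response. Compound 3 `CNC(=O)CCc1ccc(NCc2cccc(Oc3ccccc3)c2)cc1` has not yet been measured. It differs from compound 2 in one place: 2-(methylcarbamoyl)ethyl in place of (carboxymethyl)sulfanyl on an aromatic carbon. Among the compounds with values here, the only step available, a number 8 percentage points higher from compound 1 to compound 2 (within the scatter), exchanges one carboxyl-bearing group for another on the same aromatic carbon and stays within the scatter; no measured step replaces such a group by a methylcarbamoyl one, so the direction of the present change is not anchored by the data. The expectation for compound 3 is accordingly a step of a number 12 percentage points lower from compound 2 to compound 3 (beyond the scatter) in this assay, close to the scatter but with a wide range on both sides. Compound 3 is estimated at 72%, expected to fall between 45% and 95%.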

Compound 3, largest response reached (reported as percent of maximum), in percent of the reference or control that the assay uses: 67%
Compound 3: middle estimate off by 5 percentage points, on the high side, and the stated range covers the measured number.
By their numbers in this assay, from the lowest: compounds 3, 1 and 2 (each within the scatter of the next, the first and the last beyond it).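

In this assay, the aromatic carbon para to a large group tolerates a group with no carboxylic acid: compound 3, carrying 2-(methylcarbamoyl)ethyl, still gives 67%. This position now shows its first change beyond the scatter, with a number 17 percentage points lower from compound 2 to compound 3 (beyond the scatter), while the same group against 2-carboxyethenyl gives a number 9 percentage points lower from compound 1 to compound 3 (within the scatter), so the reading depends on which acid-bearing group serves as the reference, and the listed compounds do not support a general loss on replacing the acid. No measured information on the cause of this difference is available.

Still open, going by these compounds, is whether the modest step from (carboxymethyl)sulfanyl comes from losing the carboxylic acid or from the other differences between the two chains, including the sulfur and the methyl on the amide nitrogen. A 2-carboxyethyl group or a primary carboxamide on the same aromatic carbon would separate these, setting the 2-(methylcarbamoyl)ethyl chain against its direct acid and against an amide lacking that methyl.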